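Shortening the Chain of Compound 2

A few compounds are considered here, and "the series" means these few. Any claim that something is new, unique, unknown or untested is made for them only; others in the source may bear on it.

In a functional assay on SW-620 cells (Homo sapiens) for cytotoxicity (a higher number here means a weaker inhibitor, a lower number a stronger inhibitor), compound 1 `COc1ccc2nc(NC(=O)CCCCC(=O)NO)sc2c1` gives 9.07 ug/mL, while compound 2 `Cc1ccc2nc(NC(=O)CCCCCCC(=O)NO)sc2c1` gives 0.56 ug/mL. Compound 2 therefore holds the lower of the two numbers, and the gap lies beyond the scatter. Compound 3 `Cc1ccc2nc(NC(=O)CCCCC(=O)NO)sc2c1` has not yet been measured. It differs from compound 2 by a single change: hydroxycarbamoyl in place of 2-(hydroxycarbamoyl)ethyl on a saturated chain carbon, four bonds along the chain from a carbonyl carbon. In words, hydroxycarbamoyl stands in place of 2-(hydroxycarbamoyl)ethyl on a saturated chain carbon, four bonds along the chain from a carbonyl carbon. Going by the values given here, no step between measured compounds differing in one place is available, so the two values are the only guide. A clear move towards a higher number, meaning a weaker inhibitor, is expected in this assay. The expected size of this move is an 8.9-fold higher number from compound 2 to compound 3 (0.95 log units; beyond the scatter). The estimated value for compound 3 is 5 ug/mL, with an expected range of 1.8 ug/mL to 13 ug/mL.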

Compound 3, half-maximal inhibitory concentration: 4.69 ug/mL
Compound 3: the middle estimate sits 1.1-fold (0.03 log units) above what was measured; low and high end bracket the measured number.
By their numbers in this assay, from the lowest: compound 2; then compounds 3 and 1 (each within the scatter of the next).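

In this assay, the change from 3-(hydroxycarbamoyl)propyl to (hydroxycarbamoyl)methyl, with the aromatic methyl kept, gives an 8.4-fold higher number from compound 2 to compound 3 (0.92 log units; beyond the scatter), so the chain alone moves the number by a clear margin. With the shorter chain held fixed, methyl in place of methoxy on an aromatic carbon gives a 1.9-fold lower number from compound 1 to compound 3 (0.29 log units; within the scatter), which does not separate the two, and of the two single changes only the chain change has a step beyond the scatter. No measurement here explains either step.

On these data alone, whether a still longer chain would keep lowering the number, and whether the methoxy and methyl groups would also match on the longer chain, remains open. So does the effect of a carboxylic acid in place of the hydroxycarbamoyl group at the chain end.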